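Chlorophenyl Ring Change on the Shared Core

The source may report more compounds than this note shows. Statements on the series, on what has been measured and on what is new or still open speak of the compounds shown alone.

Compound 1 `O=C1CSC(c2ccc(Cl)cc2)N1CCN1CCCCC1` is the reference point of this set. For the measured compounds named here, in an ADME assay on Vero cells (Chlorocebus sabaeus) for cytotoxicity, read by neutral red uptake, tested at 12.3 ug/mL (on this read-out lower numbers stand for a stronger effect and higher numbers for a weaker effect at the one concentration tested), compound 1 gives 90%, the lowest of the three numbers so far, though compound 2 and compound 3 both sit within the scatter of it. Compound 2 `COc1ccc(C2SCC(=O)N2CCN2CCCCC2)cc1` gives 100% in this assay and compound 3 `COc1ccccc1C1SCC(=O)N1CCN1CCCCC1` gives 100%. Going by the values given here, the only single-place step measured is a number 10 percentage points higher from compound 1 to compound 2 (within the scatter). Compound 4 `O=C1CSC(c2cccc(Cl)c2)N1CCN1CCCCC1` is not yet measured; against compound 1 the change is 3-chlorophenyl in place of 4-chlorophenyl on a saturated ring carbon, at a saturated ring carbon of the shared core. Among the compounds with values here, no measured step moves a chloro group between ring positions. Within the data shown here, because a number 10 percentage points higher from compound 1 to compound 2 (within the scatter) is the sole step available and stayed within the scatter, the step of no change at the digits printed from compound 1 to compound 4 (within the scatter) is expected to stay within the scatter too. Compound 4 is estimated at 90%, with a range from 75% to 100%.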

Compound 4, a percentage reported as activity, at one concentration (the size of the read-out at that concentration, not a potency): 100%
Beside the measured number, compound 4's estimate is 10 percentage points below it; the range from low to high includes it.
By their numbers in this assay, from the lowest: compounds 1, 2, 3 and 4 (each within the scatter of the next).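

For the compounds shown here, exchanging 4-chlorophenyl for 3-chlorophenyl on the saturated ring carbon gives the first measured step that relocates the chloro group while keeping the same atoms, and in this assay it reads as a number 10 percentage points higher from compound 1 to compound 4 (within the scatter) at this position. This relocation therefore joins the exchange of chloro for methoxy, read as a number 10 percentage points higher from compound 1 to compound 2 (within the scatter), as a second step within the scatter. No evidence on the reason for this result is available.

On these data alone, whether an amine or a carboxylic acid in place of the chloro group would give a step beyond the scatter remains open. A reading at one concentration also leaves potency undefined.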